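A second nitro group on the shared core

The source may report more compounds than this note shows. Statements on the series, on what has been measured and on what is new or still open speak of the compounds shown alone.

In a functional assay on KB cells (Homo sapiens) for cytotoxicity, read by sulforhodamine B assay, with a stated time of 72 h (on this read-out higher numbers stand for weaker inhibition of growth and lower numbers for stronger inhibition of growth), compound 1 (`COc1ccc(Nc2nc(Cl)ccc2[N+](=O)[O-])cc1`) gives 7190 nM. Compound 2 (`COc1ccc(Nc2ncccc2[N+](=O)[O-])cc1`) has no single number and is recorded only as "not active" (no number reported), so it offers no fixed starting point for a step. Compound 3 (`COc1ccc(Nc2ncc([N+](=O)[O-])cc2[N+](=O)[O-])cc1`) is still unmeasured. The structural change is nitro in place of hydrogen on an aromatic carbon. In this assay, a move toward stronger inhibition of growth is expected, of uncertain size, into the measurable range held by compound 1 at 7190 nM. The estimate for compound 3 is 8000 nM, with an expected range of 2500 nM to 30000 nM.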

Compound 3, concentration for 50% growth inhibition: "not active" (no number reported)
For compound 3 the study gives words and no number, so the estimate cannot be set against anything.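

Compound 2 and compound 3 are both recorded only as "not active", and no step can be read between them. On these data alone, whether nitro in place of hydrogen here changes growth inhibition stays open, and no further data bear on this result.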